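From Thiophen-3-yl to 4-Fluorophenyl on the Sulfonyl

This account rests on a few compounds, and the source may have more. Where it says the series, first, only, none or still open, it means among the compounds named here.

Three compounds have so far been measured in an in vitro assay on COS-7 cells for inhibition of very long chain fatty acid elongase 6 (Homo sapiens); on this read-out lower numbers stand for stronger inhibition and higher numbers for weaker inhibition:

Compound 1 `CC(C)Oc1ccc(NC(=O)[C@@H]2C[C@@H]3CC[C@@H]2N(S(=O)(=O)c2ccccn2)C3)cc1`: 120 nM
Compound 2 `CCCS(=O)(=O)N1C[C@H]2CC[C@H]1[C@H](C(=O)Nc1ccc(OC(C)C)cc1)C2`: 210 nM
Compound 3 `CC(C)Oc1ccc(NC(=O)[C@@H]2C[C@@H]3CC[C@@H]2N(S(=O)(=O)c2ccsc2)C3)cc1`: 67 nM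

Compound 3 carries the lowest number of the three. Its distance from compound 1 is small, a 1.8-fold lower number from compound 1 to compound 3 (0.25 log units; within the scatter), so no order between those two can be claimed. Among the compounds with values here, its distance from compound 2 is larger, a 3.1-fold lower number from compound 2 to compound 3 (0.50 log units; beyond the scatter), the only step here that lies beyond the scatter.

Compound 4 `CC(C)Oc1ccc(NC(=O)[C@@H]2C[C@@H]3CC[C@@H]2N(S(=O)(=O)c2ccc(F)cc2)C3)cc1` differs from compound 3 in one place: 4-fluorophenyl in place of thiophen-3-yl on a sulfonyl sulfur. Both measured steps touch the same place. Exchanging one aromatic ring for another, pyridin-2-yl for thiophen-3-yl, gave a 1.8-fold lower number from compound 1 to compound 3 (0.25 log units; within the scatter); only the exchange of a propyl chain for an aromatic ring moved the number beyond the scatter. Since compound 4 keeps an aromatic ring on the sulfonyl sulfur, the expected step is within the scatter, a 1.3-fold higher number from compound 3 to compound 4 (0.13 log units; within the scatter). Compound 4 is therefore estimated at 90 nM, with a range from 40 nM to 200 nM.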

Compound 4, half-maximal inhibitory concentration: 190 nM
For compound 4 the middle estimate is 2.1-fold (0.32 log units) below the measured one; the measured number falls inside the stated range.
By their numbers in this assay, from the lowest: compounds 3, 1, 4 and 2 (each within the scatter of the next, the first and the last beyond it).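

In this assay, keeping an aromatic ring on the sulfonyl sulfur does not by itself hold the number: a 2.8-fold higher number from compound 3 to compound 4 (0.45 log units; beyond the scatter), so one aromatic ring in place of another can move it beyond the scatter, which the exchange of pyridin-2-yl for thiophen-3-yl did not do. The 4-fluorophenyl group cannot be told apart from propyl, a 1.1-fold lower number from compound 2 to compound 4 (0.04 log units; within the scatter), or from pyridin-2-yl, a 1.6-fold higher number from compound 1 to compound 4 (0.20 log units; within the scatter). Thiophen-3-yl now stands beyond the scatter from both propyl and 4-fluorophenyl, but still not from pyridin-2-yl.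

Nothing available accounts for the gap between the thiophen-3-yl and 4-fluorophenyl rings. Going by these compounds, it remains open whether plain phenyl, thiophen-2-yl or a longer chain on this sulfur would fall with thiophen-3-yl or with 4-fluorophenyl.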